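A Phenyl for a Hydroxymethyl on the Side Chain

The compounds below may be only part of what the source reports. "The series", "measured", "known", "first", "only" and "open" are said of these compounds alone.

Compound 2 `CSc1nc(NCCCCCO)c2ccccc2n1` is the starting point. In a functional assay on MCF7 cells (Homo sapiens) for cytotoxicity, read by MTT assay, with a stated time of 72 h (a higher number here means that more compound is tolerated, a lower number that less compound is tolerated), compound 2 reaches only the limit of the assay, > 100000 nM, so no number stands for it. Compound 1 `C[Se]c1nc(N)c2ccccc2n1` likewise gives a limit, > 100000 nM. Compound 3 `CSc1nc(Nc2ccccc2)c2ccccc2n1` also gives a limit, > 100000 nM. Among the measured compounds shown here, the one measured step that shares a compound with the step in question, a step that the two limits leave unreadable from compound 2 to compound 3, cannot be read, and the picture across the whole set is the same: the limit of > 100000 nM in this assay, at which 3 of the 3 values shown sit. Compound 4 `CSc1nc(NCCCCc2ccccc2)c2ccccc2n1` differs from compound 2 by phenyl in place of hydroxymethyl on a saturated chain carbon, four bonds along the chain from a nitrogen on an aromatic ring. For the measured compounds named here, no measured step gives a readable size for this kind of change, so the expectation rests on the limits alone. With every measured compound at the limit, compound 4 is expected to sit near the limit as well, an expected step of a number no higher from compound 2 to compound 4 (the limit leaves the size open). The estimate for compound 4 in this assay is 100000 nM, with an expected range from 30000 nM to 300000 nM.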

Compound 4, concentration lethal to 50% of the cells: 95900 nM
The estimate for compound 4 lay 1.0-fold (0.02 log units) above the measured number; measured number inside the range.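

In this assay, among the compounds shown here, compound 4 is the first compound here to give a real number rather than a limit, 95900 nM. Phenyl in place of hydroxymethyl on this chain carbon gives an at least 1.0-fold lower number from compound 2 to compound 4 (0.01 log units; that floor lies within the scatter), and compound 2 has only a limit, so the true size of this step is unknown and it may be no real change at all. The step from compound 2 to compound 3 cannot be read either, and the set as a whole stays at the edge of what the assay can report: the limit of > 100000 nM in this assay, at which 3 of the 4 values shown sit.

From the compounds shown here alone, whether the phenyl on the chain end drives the number down any further remains open. A longer chain carrying the same phenyl, or an amine or a carboxylic acid at the chain end in its place, could show whether this position can move the number well away from the limit.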